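The source may report more compounds than this note shows. Statements on the series, on what has been measured and on what is new or still open speak of the compounds shown alone.

Two compounds share one core and differ only in a single group on one aromatic carbon. Compound 1 `CC(=O)NCc1cccc(Cn2nc(NS(=O)(=O)c3ccc(Cl)s3)c3c(C#N)cccc32)c1` carries a cyano there, and in a functional assay on CHO cells for antagonist activity at C-C chemokine receptor type 4 (Homo sapiens), read by GTPgammaS binding (a lower number here means a stronger inhibitor, a higher number a weaker inhibitor), compound 1 gives 316 nM. Compound 2 `CC(=O)NCc1cccc(Cn2nc(NS(=O)(=O)c3ccc(Cl)s3)c3c(C(C)=O)cccc32)c1` carries an acetyl in the same position, and in this assay compound 2 gives 100 nM. For the measured compounds named here, compound 2 thus stands at the lower of the two numbers, with compound 1 as its only neighbour, and the step of a 3.2-fold lower number from compound 1 to compound 2 (0.50 log units; beyond the scatter) is the only measured step. Compound 3 `CC(=O)NCc1cccc(Cn2nc(NS(=O)(=O)c3ccc(Cl)s3)c3c(C(F)F)cccc32)c1` has not yet been measured; it differs from compound 2 in that (difluoromethyl in place of acetyl on an aromatic carbon). Going by the values given here, no measured step involves a difluoromethyl, so the one available step, a 3.2-fold lower number from compound 1 to compound 2 (0.50 log units; beyond the scatter), bears on the question only indirectly: it shows that exchanging the group at this carbon can shift the number modestly. With the acetyl of compound 2 gone, a modest rise in the number, smaller than that step, is expected. The estimate for compound 3 in this assay is 250 nM, with a range from 80 nM to 800 nM, which would mean an expected step of a 2.5-fold higher number from compound 2 to compound 3 (0.40 log units; beyond the scatter).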

Compound 3, half-maximal inhibitory concentration: 100 nM
The estimate for compound 3 lay 2.5-fold (0.40 log units) above the measured number, within the range that was stated.
By their numbers in this assay, from the lowest: compounds 2 and 3 (each within the scatter of the next); then compound 1.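

In this assay, replacing the acetyl with a difluoromethyl gives no change at the digits printed from compound 2 to compound 3 (within the scatter) and so leaves the number in place, even though the two groups share no atoms except carbon and only the acetyl has a double bond and counts a hydrogen-bond acceptor. The comparison with the nitrile gives a 3.2-fold lower number from compound 1 to compound 3 (0.50 log units; beyond the scatter) and matches a 3.2-fold lower number from compound 1 to compound 2 (0.50 log units; beyond the scatter) in size, so among these three compounds the cyano of compound 1 is the one group that stands apart, while acetyl and difluoromethyl cannot be told apart in this measurement. Nothing shown here gives a measured property that could account for this match between two such different groups or for the gap to the cyano.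

Still open, on these data alone, is how a plain methyl, a hydroxyl or an amine on this aromatic carbon would compare, and so whether any group here can bring the number clearly below the level shared by compound 2 and compound 3. Also open, as far as these compounds go, is whether a longer chain, such as a propanoyl or a butyl, would hold that level or lose it.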